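Arylsulfonamide series: chloro in place of methyl

A few compounds are considered here, and "the series" means these few. Any claim that something is new, unique, unknown or untested is made for them only; others in the source may bear on it.

Compound 3 `Cc1ccc(S(=O)(=O)N[C@H]2CC[C@@H](F)[C@@H]2C/C=C\CCC(=O)O)cc1` gives 1900 nM in a functional assay on a cell-free system (plasma) for inhibition of thromboxane A2 receptor (Homo sapiens), read by turbidimetry (a lower number here means a stronger inhibitor, a higher number a weaker inhibitor), at the upper end of the three numbers shown but within the scatter of compound 1 `O=C(O)CC/C=C\C[C@H]1[C@H](F)CC[C@@H]1NS(=O)(=O)c1ccc(Cl)c(Cl)c1`, which gives 1700 nM; compound 2 `O=C(O)CC/C=C\C[C@H]1[C@H](F)CC[C@@H]1NS(=O)(=O)c1ccc(F)cc1` gives 750 nM. Compound 4 `O=C(O)CC/C=C\C[C@H]1[C@H](F)CC[C@@H]1NS(=O)(=O)c1ccc(Cl)cc1` differs from compound 3 by chloro in place of methyl on an aromatic carbon. Among the compounds with values here, the steps that bear on this are a 2.5-fold higher number from compound 2 to compound 3 (0.40 log units; beyond the scatter) and a 2.3-fold lower number from compound 1 to compound 2 (0.36 log units; beyond the scatter), both modest and beyond the scatter, while a 1.1-fold higher number from compound 1 to compound 3 (0.05 log units; within the scatter) stays within it. A halogen on that aromatic carbon has once read lower than methyl, so a modest lowering is expected here, not necessarily reaching compound 2. The step of a 1.9-fold lower number from compound 3 to compound 4 (0.28 log units; within the scatter) is the expected outcome. Compound 4 is expected at 1000 nM, in the range 500 nM to 2000 nM.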

Compound 4, half-maximal inhibitory concentration: 210 nM
For compound 4 the middle estimate is 4.8-fold (0.68 log units) above the measured one, and the stated range ends above it.
By their numbers in this assay, from the lowest: compound 4; then compound 2; then compounds 1 and 3 (each within the scatter of the next).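

At the aromatic carbon para to a large group, chloro in place of methyl gives the largest step in the series (in this assay, a 9.0-fold lower number from compound 3 to compound 4 (0.96 log units; beyond the scatter)), and chloro in place of fluoro also reads lower (a 3.6-fold lower number from compound 2 to compound 4 (0.55 log units; beyond the scatter)), so the two halogens at this carbon are not interchangeable. Hydrogen in place of chloro on an aromatic carbon (an 8.1-fold lower number from compound 1 to compound 4 (0.91 log units; beyond the scatter)) shows that 4-chlorophenyl also reads well below 3,4-dichlorophenyl. No measurement shown here accounts for this order.

On these data alone, whether bromo or methoxy at this carbon would read near chloro remains open. So does whether the chloro advantage would persist with a longer chain carrying the carboxylic acid.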